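Replacing the Phenylethenylcarbonyl Group on a Ring Nitrogen

This account rests on a few compounds, and the source may have more. Where it says the series, first, only, none or still open, it means among the compounds named here.

Compound 1 `CCN(CC)c1ccc2cc(C(=O)c3ccc(N4CCN(C(=O)CN5CCN(C(=O)/C=C/c6ccccc6)CC5)CC4)cc3)oc2c1` was tested in an ADME assay on L02 cells (Homo sapiens) for cytotoxicity, read by MTT assay, with a stated time of 48 h (on this read-out higher numbers stand for weaker inhibition and lower numbers for stronger inhibition), and gave only a limit, > 100000 nM. It therefore stands at the top end of the measured set, with no number of its own (the limit of > 100000 nM in this assay, at which 1 of the 3 values shown sits). Compound 2 `CCN(CC)c1ccc2cc(C(=O)c3ccc(N4CCN(C(=O)CN5CCN(S(=O)(=O)c6ccc(C#N)cc6)CC5)CC4)cc3)oc2c1` gives 44100 nM in this assay, and compound 3 `CCN(CC)c1ccc2cc(C(=O)c3ccc(N4CCN(C(=O)CN5CCN(S(=O)(=O)c6ccc(F)cc6)CC5)CC4)cc3)oc2c1` gives 9240 nM.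

Compound 4 `CCN(CC)c1ccc2cc(C(=O)c3ccc(N4CCN(C(=O)CN5CCN(Cc6ccc(C(F)(F)F)cc6)CC5)CC4)cc3)oc2c1` has not been measured. It differs from compound 1 in one place (4-(trifluoromethyl)benzyl in place of (2-phenylethenyl)carbonyl on an amine nitrogen in a ring).

Two measured steps start from compound 1 and exchange the same group on the same ring nitrogen: an at least 2.2-fold lower number from compound 1 to compound 2 (0.35 log units; beyond the scatter) and an at least 10-fold lower number from compound 1 to compound 3 (1.03 log units; beyond the scatter). Between those two products, a 4.8-fold lower number from compound 2 to compound 3 (0.68 log units; beyond the scatter). Each exchange of the (2-phenylethenyl)carbonyl group moved the number downward, and the step to compound 4 also removes that group, so a downward step beyond the scatter is expected in this assay, though its size is uncertain because compound 1 offers only a limit (the limit of > 100000 nM in this assay, at which 1 of the 3 values shown sits).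

The estimate for compound 4 is 30000 nM, within 8000 nM to 120000 nM, which means an expected step of an at least 3.3-fold lower number from compound 1 to compound 4 (0.52 log units; beyond the scatter).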

Compound 4, half-maximal inhibitory concentration: 6540 nM
The estimate for compound 4 lay 4.6-fold (0.66 log units) above the measured number; the whole stated range lies above it.
By their numbers in this assay, from the lowest: compounds 4 and 3 (each within the scatter of the next); then compound 2. At a limit, above all of these: compound 1.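

The earlier compounds shown here carried only a carbonyl or a sulfonyl group on this ring nitrogen, and compound 4 shows that 4-(trifluoromethyl)benzyl, which has neither, also lowers the number in this assay, giving an at least 15-fold lower number from compound 1 to compound 4 (1.18 log units; beyond the scatter). Among the replacements, the benzyl group stays level with the (4-fluorophenyl)sulfonyl group, with a 1.4-fold lower number from compound 3 to compound 4 (0.15 log units; within the scatter), but separates from the (4-cyanophenyl)sulfonyl group, with a 6.7-fold lower number from compound 2 to compound 4 (0.83 log units; beyond the scatter). The first of these steps is only a bound, because compound 1 gave a limit and not a number: the limit of > 100000 nM in this assay, at which 1 of the 4 values shown sits.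

The compounds shown leave open what an unsubstituted benzyl group, a 4-fluorobenzyl group or a 4-cyanobenzyl group would give on this ring nitrogen. They also leave open whether a simple amine or a carboxylic acid chain would be tolerated there.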